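The compounds below may be only part of what the source reports. "The series", "measured", "known", "first", "only" and "open" are said of these compounds alone.

Measured so far in a functional assay on HCT-116 cells (Homo sapiens) for inhibition, read by MTT assay, with a stated time of 48 h; on this read-out lower numbers stand for stronger inhibition and higher numbers for weaker inhibition: compound 1 `COCC(=O)N(Cc1ccc(OC)c(O)c1)c1cc(OC)c(OC)c(OC)c1` gives 230 nM; compound 2 `COc1ccc(CN(C(C)=O)c2cc(OC)c(OC)c(OC)c2)cc1O` gives 270 nM; compound 3 `CCC(=O)N(Cc1ccc(OC)c(O)c1)c1cc(OC)c(OC)c(OC)c1` gives 61 nM.

Compound 3 has the lowest number of the three, and both of its steps lie beyond the scatter: a 3.8-fold lower number from compound 1 to compound 3 (0.58 log units; beyond the scatter) and a 4.4-fold lower number from compound 2 to compound 3 (0.65 log units; beyond the scatter). It is therefore the most potent of the measured compounds. Compound 4 `C=CC(=O)N(Cc1ccc(OC)c(O)c1)c1cc(OC)c(OC)c(OC)c1` differs from compound 3 by vinyl in place of ethyl on a carbonyl carbon. For the measured compounds named here, the two measured steps only alter the group on the saturated chain carbon bound to the carbonyl carbon, and each is modest; no measured step exchanges ethyl for vinyl, so the effect of this change is untested. On that basis compound 4 is expected to stay close to compound 3, with a 1.1-fold higher number from compound 3 to compound 4 (0.06 log units; within the scatter) as the estimated step, giving an estimate of 70 nM for compound 4, within a range of 25 nM to 200 nM.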

Compound 4, half-maximal inhibitory concentration: 98 nM
For compound 4 the middle estimate is 1.4-fold (0.15 log units) below the measured one; low and high end bracket the measured number.
By their numbers in this assay, from the lowest: compounds 3 and 4 (each within the scatter of the next); then compounds 1 and 2 (each within the scatter of the next).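

In this assay, vinyl in place of ethyl on a carbonyl carbon gives a step that stays within the scatter, a 1.6-fold higher number from compound 3 to compound 4 (0.21 log units; within the scatter), so this position accepts a double bond without a measurable change. Vinyl also keeps its advantage over the other two groups at this position, with a 2.8-fold lower number from compound 2 to compound 4 (0.44 log units; beyond the scatter) and a 2.3-fold lower number from compound 1 to compound 4 (0.37 log units; beyond the scatter). No measurement shown here explains these differences. Still open, as far as these compounds go, is whether a longer chain such as propyl, a cyclopropyl ring or an amine on the carbonyl carbon would give a number as low as these.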